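This account rests on a few compounds, and the source may have more. Where it says the series, first, only, none or still open, it means among the compounds named here.

Two compounds of this series have been run in an ADME assay on microsomes from liver (Mus musculus) for metabolic stability, read by LC-MS, using NADPH, tested at 10 uM; a lower number here means that the compound disappears faster, a higher number that the compound lasts longer. Compound 1, `Cc1ccccc1S(=O)(=O)N1CCN(c2ccc(C(=O)NCc3cccs3)nn2)CC1`, gives 0.0333 h in this assay. Compound 2, `O=C(NCc1ccc(F)cc1)c1ccc(N2CCN(S(=O)(=O)c3ccccc3C(F)(F)F)CC2)nn1`, gives 0.517 h in this assay, which is the higher of the two numbers; the gap between compound 2 and compound 1 lies well beyond the scatter of repeated measurements, so compound 2 is the longer-lived of the pair on the evidence at hand.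

Compound 3, `Nc1ncccc1S(=O)(=O)N1CCN(c2ccc(C(=O)NCc3ccc(F)cc3)nn2)CC1`, has not yet been measured. It differs from compound 2 in one place only: 2-aminopyridin-3-yl in place of 2-(trifluoromethyl)phenyl on a sulfonyl sulfur. The core and the amide part are unchanged.

Nothing in the two measured compounds shows how this particular exchange on the sulfonyl sulfur plays out, since they differ from each other in more than one place. What they do show is that the group on the sulfonyl sulfur can move the half-life a long way. Compound 3 is therefore expected to sit somewhat below compound 2, with the step of a 2.1-fold lower number from compound 2 to compound 3 (0.32 log units; beyond the scatter) expected to be of modest size, downward, and possibly not beyond the scatter. The estimate for compound 3 is 0.25 h, with a likely range from 0.06 h to 0.9 h.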

Compound 3, half-life: 0.317 h
The estimate for compound 3 lay 1.3-fold (0.10 log units) below the measured number; the measured number falls inside the stated range.
By their numbers in this assay, from the lowest: compound 1; then compounds 3 and 2 (each within the scatter of the next).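

In this assay, within the data shown here, the exchange of 2-(trifluoromethyl)phenyl for 2-aminopyridin-3-yl on a sulfonyl sulfur gives a 1.6-fold lower number from compound 2 to compound 3 (0.21 log units; within the scatter) and is the only change at this position that can be read on its own. With the core and the amide part held fixed, these two groups cannot be told apart in this read-out, even though the entering group brings a ring hetero atom, a hydrogen-bond donor and hydrogen-bond acceptors that the leaving group lacks, and has fewer heavy atoms. Nothing at hand accounts for the two groups reading alike.

The compounds shown do not settle how much of the difference between compound 1 and compound 2 belongs to the group on the sulfonyl sulfur and how much to the amide part, since those two differ in more than one place. On these data alone, it also stays open whether any single exchange here can move the half-life beyond the scatter, for instance an unsubstituted phenyl, a methoxy-bearing phenyl or a saturated cyclohexyl on the sulfonyl sulfur.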